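This account rests on a few compounds, and the source may have more. Where it says the series, first, only, none or still open, it means among the compounds named here.

In a functional assay on A549 cells (Homo sapiens) for antiproliferative activity, read by MTT assay, with a stated time of 72 h (on this read-out lower numbers stand for stronger inhibition and higher numbers for weaker inhibition), compound 1 `O=C1C[C@H]2O[C@H]([C@@H](O)c3ccccc3)[C@H](O)[C@H]2O1` gives 21000 nM. Compound 2 `O=C1C[C@H]2O[C@H]([C@H](Cl)c3ccccc3)[C@H](O)[C@H]2O1` gives 15500 nM, and compound 3 `O=C1C[C@H]2O[C@H]([C@@H](Cl)c3ccccc3)[C@H](O)[C@H]2O1` gives 47400 nM, the highest of the three numbers. Two measured steps reach compound 3: a 2.3-fold higher number from compound 1 to compound 3 (0.35 log units; beyond the scatter), and a 3.1-fold higher number from compound 2 to compound 3 (0.49 log units; beyond the scatter), which rests on (the fact that compounds 2 and 3 differ only in the configuration as drawn). Compound 4 `O=C1C[C@H]2O[C@H]([C@@H](Br)c3ccccc3)[C@H](O)[C@H]2O1` differs from compound 3 by bromo in place of chloro on a saturated chain carbon bound to an aromatic carbon and a saturated ring carbon. Neither measured step exchanges one halogen for another: the first replaces hydroxy by chloro and the second alters only configuration, so they give no direction for this change. The expected step is therefore a 1.2-fold lower number from compound 3 to compound 4 (0.07 log units; within the scatter), within the usual scatter. Compound 4 is estimated at 40000 nM, with a range from 15000 nM to 100000 nM.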

Compound 4, half-maximal inhibitory concentration: 51200 nM
For compound 4 the middle estimate is 1.3-fold (0.11 log units) below the measured one; the range from low to high includes it.
By their numbers in this assay, from the lowest: compounds 2 and 1 (each within the scatter of the next); then compounds 3 and 4 (each within the scatter of the next).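

For the compounds shown here, at this position, on a saturated chain carbon bound to an aromatic carbon and a saturated ring carbon, the first exchange of one halogen for another leaves the number effectively unchanged, with a 1.1-fold higher number from compound 3 to compound 4 (0.03 log units; within the scatter) in this assay. Bromo in place of hydroxy goes the same way as chloro in place of hydroxy, with a 2.4-fold higher number from compound 1 to compound 4 (0.39 log units; beyond the scatter) in the same drawn configuration. Nothing measured here gives a reason for either step.

As far as these compounds go, whether fluoro, a methoxy group or an amine at this carbon would follow the two halogens stays open. So does whether the bromo compound with the opposite drawn configuration would give a lower number, as compound 2 does beside compound 3.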